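The source may hold more compounds than are shown below. What is called first, only, known or untested is meant among the compounds shown, and "the series" means these compounds.

In a physicochemical assay for solubility, in phosphate buffer, measured as kinetic solubility, at pH 7.4, tested at 250 uM (a higher number here means a more soluble compound, a lower number a less soluble compound), compound 1 (`CCCCCCNc1ccc(C(=O)O)cc1S(=O)(=O)NC`) gives 247000 nM and compound 2 (`CNS(=O)(=O)c1cc(C(=O)O)ccc1NCCCCCCCC(F)(F)F`) gives 242000 nM, so compound 2 stands level with compound 1 within the scatter. Among the compounds with values here, the only measured step is a 1.0-fold lower number from compound 1 to compound 2 (0.01 log units; within the scatter). That step concerns the saturated chain, not the sulfonamide nitrogen, so it bears on the next change only indirectly. Compound 3 (`O=C(O)c1ccc(NCCCCCCCC(F)(F)F)c(S(=O)(=O)NC2CCCCC2)c1`) carries cyclohexyl in place of methyl on a sulfonamide nitrogen. Within the data shown here, no measured pair shows a change at that nitrogen, so the data give no direct size for it. In this assay, a moderate move to a lower number is expected, but this rests on the structural change alone and remains uncertain. The expected step is a 1.6-fold lower number from compound 2 to compound 3 (0.21 log units; within the scatter). Compound 3 is estimated at 150000 nM, with an expected range of 50000 nM to 250000 nM.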

Compound 3, solubility: 9000 nM
Compound 3: middle estimate off by 17-fold (1.22 log units), on the high side; measured number outside the range, below it.
By their numbers in this assay, from the lowest: compound 3; then compounds 2 and 1 (each within the scatter of the next).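

In this assay, the group on the sulfonamide nitrogen proves to matter far more than the earlier change on the saturated chain: cyclohexyl in place of methyl gives a 27-fold lower number from compound 2 to compound 3 (1.43 log units; beyond the scatter), whereas the chain change gave a 1.0-fold lower number from compound 1 to compound 2 (0.01 log units; within the scatter). Within the data shown here, this is the first measured change at that nitrogen, and it shows that the read-out is not insensitive across the series, as the first two compounds alone might have suggested. No measurement at hand explains why this step is so large.

The compounds shown leave open whether the step follows from the ring itself or from the added carbon, which a small cyclopropyl or an open hexyl chain on that nitrogen could help separate. They also leave open whether a cyclohexyl ring carrying a hydroxyl or an amine would give a different number.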